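Adding a propyl to the most active of three compounds

This account rests on a few compounds, and the source may have more. Where it says the series, first, only, none or still open, it means among the compounds named here.

Measured in a functional assay on MCF7 cells (Homo sapiens) for antiproliferative activity, read by MTT assay, with a stated time of 48 h; on this read-out higher numbers stand for weaker inhibition and lower numbers for stronger inhibition:
- compound 1 `C=C(/C=C/c1ccc(OC)c(N)c1)c1cc(OC)c(OC)c(OC)c1`: 786 nM
- compound 2 `CC=C(/C=C/c1ccc(OC)c(N)c1)c1cc(OC)c(OC)c(OC)c1`: 247 nM
- compound 3 `C=C(/C(C)=C/c1ccc(OC)c(O)c1)c1cc(OC)c(OC)c(OC)c1`: 89 nM

Compound 3 gives the lowest number of the three, and its gaps to both others lie beyond the usual scatter, so it is the strongest inhibitor so far. Compound 4 `CCCC=C(/C(C)=C/c1ccc(OC)c(O)c1)c1cc(OC)c(OC)c(OC)c1` carries one change from compound 3: propyl in place of hydrogen on a double-bonded chain carbon bound to a double-bonded chain carbon.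

Going by the values given here, only one measured step resembles this change. Methyl in place of hydrogen at the same kind of carbon gave a 3.2-fold lower number from compound 1 to compound 2 (0.50 log units; beyond the scatter), a modest drop beyond the scatter. That step is an imperfect guide. Methyl is not propyl, and compound 1 and compound 2 differ from compound 3 elsewhere in their structures. A lower number in this assay is therefore expected, but only a slight one, quite possibly within the scatter. The expected change is a 1.3-fold lower number from compound 3 to compound 4 (0.10 log units; within the scatter). Compound 4 is estimated at 70 nM, with an expected range of 18 nM to 280 nM.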

Compound 4, half-maximal inhibitory concentration: 3970 nM
For compound 4 the middle estimate is 57-fold (1.75 log units) below the measured one, and the stated range ends below it.
By their numbers in this assay, from the lowest: compound 3; then compound 2; then compound 1; then compound 4.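

In this assay, this kind of carbon turns out not to respond in one direction: propyl in place of hydrogen gives a 45-fold higher number from compound 3 to compound 4 (1.65 log units; beyond the scatter) and so much weaker inhibition, whereas methyl in place of hydrogen gave a 3.2-fold lower number from compound 1 to compound 2 (0.50 log units; beyond the scatter) on a different parent compound. A favourable step with methyl therefore does not carry over to propyl on the core of compound 3, and the outcome at this carbon is shown to vary widely with the group added, the parent compound, or both. No measurement offered here explains why the two steps point in opposite directions.

The compounds shown cannot separate the effect of the added group from that of the parent compound. As far as these compounds go, how a methyl or an ethyl at this carbon would behave on the core of compound 3 remains open, as does the effect of an amine or a carboxylic acid there.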